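The compounds below may be only part of what the source reports. "The series", "measured", "known", "first", "only" and "open" are said of these compounds alone.

Working notes on the series.

Compound 1, `C[C@@H](O)[C@H]1C(=O)N2C3=C(S[C@@H]4CN[C@@H](C4)C(=O)Nc4cccc(c4)C(=O)OCc4oc(=O)oc4COC3=O)[C@H](C)[C@H]12`, is read in an ADME assay for metabolic stability, read by LC-MS, with a stated time of 3 h, at pH 6.5, tested at 50 uM; on this read-out lower numbers stand for a less stable compound and higher numbers for a more stable compound. In this assay compound 1 gives > 95%, which is a limit of the assay and not a number. Compound 2, `CC(=O)O[C@H](C)[C@H]1C(=O)N2C3=C(S[C@@H]4CN[C@@H](C4)C(=O)Nc4cccc(c4)C(=O)OCOCOC3=O)[C@H](C)[C@H]12`, is the second measured member. In this assay compound 2 gives > 95%, again a limit rather than a number. Among the measured compounds shown here, compound 1 therefore stands at the upper edge of what the assay can report, as does the one other value shown, (the limit of > 95% in this assay, at which 2 of the 2 values shown sit); no single-change step between measured compounds can be drawn, and of the pair only this much is known.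

Compound 3, `Cc1oc(=O)oc1COC(=O)N1C[C@@H]2C[C@H]1C(=O)Nc1cccc(c1)C(=O)OCc1oc(=O)oc1COC(=O)C1=C(S2)[C@H](C)[C@@H]2[C@@H]([C@@H](C)O)C(=O)N12`, is not yet measured in this assay. Against compound 1 it carries a group of 11 heavy atoms (6 carbon, 5 oxygen; one five-membered aromatic ring with 2 hetero atoms) in place of a hydrogen atom, on an amine nitrogen in a ring. For the measured compounds named here, no measured step bears on this change, so the expectation rests on compound 1 sitting at the limit > 95% with the rest of the core kept intact. The step from compound 1 to compound 3 is expected to be a number at least 5 percentage points lower from compound 1 to compound 3 (that floor lies within the scatter), none beyond the usual scatter or a small loss. Compound 3 is estimated at 90%, within 70% to 99%.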

Compound 3, percent of the compound remaining in the ADME assay: > 95%
Compound 3: no number, only a limit (the forecaster's own chance of this, stated with the estimate: 50%); at least 5 percentage points between middle value and limit.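

In a physicochemical assay for metabolic stability, read by LC-MS, in phosphate buffer, with a stated time of 3 h, at pH 7.4, tested at 50 uM (on this read-out lower numbers stand for a less stable compound and higher numbers for a more stable compound), compound 1 gives > 95%, a limit of the assay and not a number. In the physicochemical assay compound 3 gives > 95%, also a limit. The step between compound 1 and compound 3 cannot be read in the ADME assay or in the physicochemical assay. As far as these compounds go, whether the group of 11 heavy atoms on the amine nitrogen in a ring changes the percent of compound remaining stays open.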